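A Methoxy Added to a Silyl-Protected Scaffold

The compounds below may be only part of what the source reports. "The series", "measured", "known", "first", "only" and "open" are said of these compounds alone.

Compound 1, `COc1ccc(C2=C(c3cc(OC)c(OC)c(OC)c3)C(=O)CC2O[SiH2]C(C)(C)C)cc1OC`: > 100 ug/mL
Compound 2, `COc1ccc(C2=C(c3cc(OC)c(OC)c(OC)c3)CC(O)C2=O)cc1[N+](=O)[O-]`: > 100 ug/mL

In an ADME assay on PA-1 cells (Homo sapiens) for cytotoxicity, read by MTT assay, with a stated time of 72 h (a higher number here means a weaker inhibitor, a lower number a stronger inhibitor), compound 1 gives only a limit, > 100 ug/mL, and not a number. Compound 2 likewise gives only a limit in this assay, > 100 ug/mL. Within the data shown here, both values therefore sit at the limit of > 100 ug/mL in this assay, at which 2 of the 2 values shown sit, so no measured step exists that could show how a change to the shared core of compound 1 moves the reading.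

Compound 3, `COCOc1cc(C2=C(c3cc(OC)c(OC)c(OC)c3)C(=O)CC2O[SiH2]C(C)(C)C)ccc1OC`, carries one change relative to compound 1: methoxy in place of hydrogen on a saturated chain carbon bound to an oxygen on an aromatic ring. The rest of the structure is unchanged.

Among the measured compounds shown here, no pair of measured compounds is separated by a single change, so the size of this step cannot be read from the data. With both known values resting at the limit, compound 3 is expected to show no step beyond the scatter, a step that the limit leaves unreadable from compound 1 to compound 3, and most likely to be reported as a limit again. The estimate for compound 3 in this assay is 120 ug/mL, within 50 ug/mL to 300 ug/mL.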

Compound 3, half-maximal inhibitory concentration: 13.5 ug/mL
Compound 3: the middle estimate sits 8.9-fold (0.95 log units) above what was measured; measured number outside the range, below it.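

In this assay compound 1 gives only a limit, > 100 ug/mL, and not a number. Methoxy in place of hydrogen on a saturated chain carbon bound to an oxygen on an aromatic ring turns 3,4-dimethoxyphenyl into 4-methoxy-3-(methoxymethoxy)phenyl and gives an at least 7.4-fold lower number from compound 1 to compound 3 (0.86 log units; beyond the scatter), a step that starts from that limit and so gives only its smallest possible size. This position is therefore one where a single change brings the reading off the limit, which the earlier compounds could not show: the limit of > 100 ug/mL in this assay, at which 2 of the 3 values shown sit.

Methoxymethoxy is the only group shown to do this here, so it remains open whether a longer chain, an amine or a carboxylic acid at this place would do the same. On these data alone, whether the same change would act on other compounds also remains open.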